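This account rests on a few compounds, and the source may have more. Where it says the series, first, only, none or still open, it means among the compounds named here.

Compound 1 `O=C(NNc1cccc(Cl)c1)c1ccc(NS(=O)(=O)c2cnc(O)nc2O)cc1`: 8410 nM
Compound 2 `O=C(NNc1ccccc1F)c1ccc(NS(=O)(=O)c2cnc(O)nc2O)cc1`: > 20000 nM
Compound 3 `O=C(NNc1ccc(F)cc1)c1ccccc1NS(=O)(=O)c1cnc(O)nc1O`: > 20000 nM

In a functional assay on OVCAR-3 cells (Homo sapiens) for antiproliferative activity, read by MTT assay, with a stated time of 24 h (on this read-out higher numbers stand for weaker inhibition and lower numbers for stronger inhibition), compound 2 gives > 20000 nM, which is a limit and not a number. The same holds for compound 3, so the weak end of these data is the limit of > 20000 nM in this assay, at which 2 of the 3 values shown sit.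

Compound 4 `Cc1ccccc1C(=O)NNC(=O)c1ccc(NS(=O)(=O)c2cnc(O)nc2O)cc1` carries (2-methylphenyl)carbonyl in place of 2-fluorophenyl on an amine nitrogen. Within the data shown here, the only measured step is an at least 2.3-fold higher number from compound 1 to compound 2 (0.37 log units; beyond the scatter). It swaps one substituted phenyl for another and brings in no carbonyl, so it offers only a loose guide. No clear step in either direction is therefore expected, and compound 4 should stay near that limit. The expected change is a number no higher from compound 2 to compound 4 (the limit leaves the size open). For compound 4 the estimate is 20000 nM, with an expected range of 8000 nM to 50000 nM.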

Compound 4, half-maximal inhibitory concentration: > 20000 nM
Compound 4: only a limit was reported (the forecaster's own chance of this, stated with the estimate: 60%); the middle value sits exactly at the limit.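

In this assay, among these compounds, a ring joined to this amine nitrogen through a carbonyl is now tested for the first time, and (2-methylphenyl)carbonyl gives an at least 2.3-fold higher number from compound 1 to compound 4 (0.37 log units; beyond the scatter). This carbonyl-linked group therefore joins 2-fluorophenyl in falling short of 3-chlorophenyl at this position. The values of compound 2 and compound 4 are both limits, so the step between them cannot be read, and the series now gathers at its weak end: the limit of > 20000 nM in this assay, at which 3 of the 4 values shown sit.

On these data alone, whether (3-chlorophenyl)carbonyl would keep the activity of compound 1 stays open. So does the effect of the carbonyl link when the ring substituent stays the same.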